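Turning the amide around in compound 1

The source may hold more compounds than are shown below. What is called first, only, known or untested is meant among the compounds shown, and "the series" means these compounds.

In an ADME assay on microsomes from liver (Mus musculus) for metabolic stability, with a stated time of 10 min, tested at 0.5 uM (on this read-out lower numbers stand for a less stable compound and higher numbers for a more stable compound), compound 1 (`C[C@@H](C(=O)NC1CCCCC1)[C@H]1CC[C@@H](c2ccnc3ccc(F)cc32)CC1`) gives < 1%, which is a limit and not a number. It therefore stands at the limit of < 1% in this assay, at which 1 of the 3 values shown sits.

Compound 4 (`C[C@@H](NC(=O)C1CCCCC1)[C@H]1CC[C@@H](c2ccnc3ccc(F)cc32)CC1`) has the same atoms as compound 1, joined differently: (cyclohexylcarbonyl)amino in place of cyclohexylcarbamoyl on a saturated chain carbon bound to a saturated chain carbon and a saturated ring carbon. Among the measured compounds shown here, no measured pair shows this exchange directly, so the nearest evidence comes from two compounds that share the amide orientation of compound 4 and differ from it in the group on the carbonyl carbon. Compound 2 (`C[C@@H](NC(=O)c1cccc(Cl)c1)[C@H]1CC[C@@H](c2ccnc3ccc(F)cc32)CC1`) gives 9%, and compound 3 (`C[C@@H](NC(=O)C12CCC(Cl)(CC1)CC2)[C@H]1CC[C@@H](c2ccnc3ccc(F)cc32)CC1`) gives 10%. Between them lies a number 1 percentage points higher from compound 2 to compound 3 (within the scatter), so swapping that group gave no step beyond the scatter in this pair.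

On the strength of those two values, the change is expected to move the read-out upward, towards a more stable compound, though perhaps not beyond the scatter. The expected step is a number at least 6 percentage points higher from compound 1 to compound 4 (that floor lies within the scatter). Compound 4 is estimated at 7%, with an expected range from 1% to 16%.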

Compound 4, percent of the compound remaining: 5%
For compound 4 the middle estimate is 2 percentage points above the measured one, and the stated range covers the measured number.
By their numbers in this assay, from the lowest: compounds 4, 2 and 3 (each within the scatter of the next). At a limit, below all of these: compound 1.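

Reversing the amide, with (cyclohexylcarbonyl)amino in place of cyclohexylcarbamoyl, now has a direct reading in this assay: it gives a number at least 4 percentage points higher from compound 1 to compound 4 (that floor lies within the scatter) and so does not establish a gain beyond the scatter. The value of compound 1 is a limit and not a number, so this step has only a floor: the limit of < 1% in this assay, at which 1 of the 4 values shown sits. With the reversed amide, the group on the carbonyl carbon also makes no step beyond the scatter, as cyclohexyl gives a number 5 percentage points lower from compound 3 to compound 4 (within the scatter) and a number 4 percentage points lower from compound 2 to compound 4 (within the scatter).

The compounds shown leave open how far the real step from compound 1 to compound 4 extends. They also leave open whether a morpholine or a carboxylic acid on the carbonyl carbon would move the read-out beyond the scatter of compound 2, compound 3 and compound 4.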